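A few compounds are considered here, and "the series" means these few. Any claim that something is new, unique, unknown or untested is made for them only; others in the source may bear on it.

Measured so far:
compound 1, `Cn1cc(/C=C/C(=O)c2ccc(Cl)cc2)cc1/C=C/C(=O)NO`, which in an assay on isolated protein for inhibition of histone deacetylase HD1B (Zea mays) (a lower number here means a stronger inhibitor, a higher number a weaker inhibitor), gives 29400 nM;
compound 2, `C/C(=C\c1cc(/C=C/C(=O)NO)n(C)c1)C(=O)c1ccccc1`, which in this assay gives 570 nM.

Of these two numbers, compound 1 holds the higher one in this assay, so it is the weaker inhibitor of the pair; compound 2 sits far lower, and the gap between the two lies well beyond the scatter. Compound 2, however, differs from compound 1 in more than one place, so its value says nothing direct about any single change.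

Compound 3, `Cn1cc(/C=C/C(=O)c2cccs2)cc1/C=C/C(=O)NO`, differs from compound 1 in one place only: thiophen-2-yl in place of 4-chlorophenyl on a carbonyl carbon. Within the data shown here, no pair among the measured compounds shows this change, so its effect in this assay is unknown. With the rest of the structure held, the step is expected to be modest, and the estimated change from compound 1 to compound 3 is a 1.5-fold lower number from compound 1 to compound 3 (0.17 log units; within the scatter). For compound 3 the expected value in this assay is 20000 nM, with a range from 6000 nM to 60000 nM.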

Compound 3, half-maximal inhibitory concentration: 25800 nM
For compound 3 the middle estimate is 1.3-fold (0.11 log units) below the measured one; low and high end bracket the measured number.
By their numbers in this assay, from the lowest: compound 2; then compounds 3 and 1 (each within the scatter of the next).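

Among these compounds, the exchange at this carbonyl carbon gives the first direct reading of the position in this assay (a 1.1-fold lower number from compound 1 to compound 3 (0.06 log units; within the scatter)), and compound 1 and compound 3 cannot be told apart. On this core, thiophen-2-yl, with its five-membered aromatic ring and one hydrogen-bond acceptor, and 4-chlorophenyl, with its six-membered aromatic ring of carbon only and no such acceptor, therefore read the same. No measurement at hand accounts for this result.

The compounds shown leave open whether the chlorine matters at all, since unsubstituted phenyl does not appear among them. They also leave open whether a group of another kind on this carbonyl carbon, such as a pyridine ring, a carboxylic acid or a simple methyl, would separate from these two.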